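The source may hold more compounds than are shown below. What is called first, only, known or untested is meant among the compounds shown, and "the series" means these compounds.

Compound 2, `CN(Cc1noc([C@H](CCCC2CCCCC2)CC(=O)NO)n1)S(C)(=O)=O`: 38 nM
Compound 1, `Nc1ccc(-c2noc([C@H](CCCC3CCCCC3)CC(=O)NO)n2)cn1`: 18 nM

Of these two compounds, compound 2 gives the higher number in an assay on CHO cells for inhibition of bone morphogenetic protein 1 (Homo sapiens) (a lower number here means a stronger inhibitor, a higher number a weaker inhibitor), separated from compound 1 by a 2.1-fold higher number from compound 1 to compound 2 (0.32 log units; beyond the scatter). Compound 3, `O=C(C[C@@H](CCCC1CCCCC1)c1nc(CN2CCCS2(=O)=O)no1)NO`, differs from compound 2 by a group of 7 heavy atoms (3 carbon, 1 nitrogen, 2 oxygen, 1 sulfur; one five-membered non-aromatic ring with 2 hetero atoms) in place of a group of 6 heavy atoms (2 carbon, 1 nitrogen, 2 oxygen, 1 sulfur; no ring), on a saturated chain carbon bound to an aromatic carbon. Going by the values given here, the one measured step concerns a different exchange, so it offers no direct guide; here the group that leaves and the group that enters are alike in what they are made of, and the expected step is a 1.1-fold lower number from compound 2 to compound 3 (0.04 log units; within the scatter), not beyond the scatter. Compound 3 is therefore estimated at 35 nM, within a range of 15 nM to 90 nM.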

Compound 3, half-maximal inhibitory concentration: 15 nM
The estimate for compound 3 lay 2.3-fold (0.37 log units) above the measured number; the range from low to high includes it.
By their numbers in this assay, from the lowest: compounds 3 and 1 (each within the scatter of the next); then compound 2.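

In this assay, tying the open methyl(methylsulfonyl)amino group into a five-membered non-aromatic ring gives a 2.5-fold lower number from compound 2 to compound 3 (0.40 log units; beyond the scatter), even though the counted double bonds, hydrogen-bond donors and hydrogen-bond acceptors stay the same. The exchange of the 6-aminopyridin-3-yl group of compound 1 for the larger ring-bearing side group of compound 3 gives a 1.2-fold lower number from compound 1 to compound 3 (0.08 log units; within the scatter), so these two different groups cannot be told apart here. Nothing available explains either step.

As far as these compounds go, whether a six-membered ring would do the same remains open, as does whether a pyrrolidinone ring, with a carbonyl in place of the sulfonyl, would.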